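A Trifluoromethyl Extension on an Inactive Brominated Phenol

A few compounds are considered here, and "the series" means these few. Any claim that something is new, unique, unknown or untested is made for them only; others in the source may bear on it.

Compound 2 `C=C1C[C@]23C[C@@]1(O)CC[C@H]2c1cc(Br)c(O)c(C)c1[C@@H]3Cn1cc(-c2ccccc2)nn1` is the starting point. In a functional assay on SW480 cells (Homo sapiens) for cytotoxicity, read by MTT assay, with a stated time of 4 days (a lower number here means a stronger inhibitor, a higher number a weaker inhibitor), compound 2 gives > 20000 nM, which is a limit of the assay and not a number. Its parent compound 1 `C=C1C[C@]23C[C@@]1(O)CC[C@H]2c1ccc(O)c(C)c1[C@@H]3Cn1cc(-c2ccccc2)nn1` stands at the same place. In this assay compound 1 gives > 20000 nM, again a limit. The step that the two limits leave unreadable from compound 1 to compound 2 cannot be read, because both values sit at the limit of > 20000 nM in this assay, at which 2 of the 2 values shown sit. Compound 3 `C=C1C[C@]23C[C@@]1(O)CC[C@H]2c1cc(Br)c(O)c(C)c1[C@@H]3Cn1cc(-c2ccc(C(F)(F)F)cc2)nn1` carries the change (trifluoromethyl in place of hydrogen on an aromatic carbon). For the measured compounds named here, no measured step touches the phenyl group, and the only measured step is unreadable, so the expectation rests solely on where compound 2 stands. For compound 3 the expected step is a step that the limit leaves unreadable from compound 2 to compound 3 in this assay, nothing beyond the scatter. Compound 3 is therefore estimated at 25000 nM, within 8000 nM to 80000 nM, and most likely reported once more only as a limit.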

Compound 3, half-maximal inhibitory concentration: 15200 nM
Compound 3: the middle estimate sits 1.6-fold (0.22 log units) above what was measured, and the stated range covers the measured number.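

In this assay compound 3 gives 15200 nM, the only actual number among the three compounds shown, so this position on the phenyl can carry a change that brings a reading inside the range of the assay. The change from phenyl to 4-(trifluoromethyl)phenyl, para to a large group, gives an at least 1.3-fold lower number from compound 2 to compound 3 (0.11 log units; that floor lies within the scatter). The true size of that step stays unknown, because one end of it is a limit: the limit of > 20000 nM in this assay, at which 2 of the 3 values shown sit.

Open, on these data alone, is how a chlorine, a methoxy group or a carboxylic acid in the same place on the phenyl would read in this assay, and so whether the number of compound 3 belongs to trifluoromethyl in particular. Open too, as far as these compounds go, is whether that number depends on the bromo, which would take the 4-(trifluoromethyl)phenyl compound with hydrogen in place of bromo.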